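Chloro for Fluoro: Expected Cytotoxicity of Compound 4

This account rests on a few compounds, and the source may have more. Where it says the series, first, only, none or still open, it means among the compounds named here.

Measured compounds:
compound 1 `Oc1cc(C(F)(F)F)ccc1-c1nc(-c2ccccc2O)n(-c2ccccc2F)n1` gives 100%
compound 2 `Oc1cc(C(F)(F)F)ccc1-c1nc(-c2ccccc2O)n(-c2ccccc2Cl)n1` gives 102%
compound 3 `Oc1cc(C(F)(F)F)ccc1-c1nc(-c2ccccc2O)n(-c2cccc(F)c2)n1` gives 98.3%

All three were tested in a functional assay on PC-12 cells (Rattus norvegicus) for cytotoxicity, read by MTT assay, with stated times of 2 h and 24 h, tested at 10 uM; a higher number here means a stronger effect of the compound at the concentration tested, a lower number a weaker effect. Compound 1 and compound 2 share one core and differ only by chloro in place of fluoro on an aromatic carbon; that change made a number 2 percentage points higher from compound 1 to compound 2 (within the scatter). Compound 3 differs from compound 1 in its core by 3-fluorophenyl in place of 2-fluorophenyl on an aromatic nitrogen.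

Compound 4 `Oc1cc(C(F)(F)F)ccc1-c1nc(-c2ccccc2O)n(-c2cccc(Cl)c2)n1` has not been measured. It differs from compound 3 by chloro in place of fluoro on an aromatic carbon. Within the data shown here, this is the same kind of change as the one from compound 1 to compound 2, but not the same: there the chloro sits ortho to a large group, here it sits meta to a large group.

Since that earlier change gave a number 2 percentage points higher from compound 1 to compound 2 (within the scatter), the step from compound 3 to compound 4 in this assay is expected to be a number 1.7 percentage points higher from compound 3 to compound 4 (within the scatter), resting on that single earlier pair alone. Compound 4 is therefore estimated at 100%, with a range from 90% to 110%.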

Compound 4, a percentage reported as activity, at one concentration (the size of the read-out at that concentration, not a potency): 100%
Compound 4: middle estimate and measured number agree at the digits printed; low and high end bracket the measured number.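

Chloro in place of fluoro carried over from the core of compound 1 to the core of compound 3 in this assay without a gap that stands out from the scatter: the same change on two cores in this assay, a number 2 percentage points higher (within the scatter) from compound 1 to compound 2 and a number 1.7 percentage points higher (within the scatter) from compound 3 to compound 4, 0.3 percentage points apart, within the scatter of two such steps

The other new comparisons also stay small, with a number 1.7 percentage points higher from compound 3 to compound 4 (within the scatter) for the change itself, a number 2 percentage points lower from compound 2 to compound 4 (within the scatter) for 3-chlorophenyl in place of 2-chlorophenyl, and no change at the digits printed from compound 1 to compound 4 (within the scatter) for 3-chlorophenyl in place of 2-fluorophenyl. Among these compounds, this shows only that the change did little on either core in this one assay at one concentration; two small steps that agree are a weak test and do not show that a larger step would carry over in the same way, nor do they make a rule for the series.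

The compounds shown leave open how this read-out responds to other groups on that phenyl ring, such as an amine, a carboxylic acid or a longer alkyl chain. They also leave open whether chloro in place of fluoro would behave alike on a third core.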